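A few compounds are considered here, and "the series" means these few. Any claim that something is new, unique, unknown or untested is made for them only; others in the source may bear on it.

Compound 1 `Cc1nc2c(cnn2-c2ccccc2)c(=O)n1-c1cccc(Cl)c1` in an in vitro functional assay on cells for antagonist activity at metabotropic glutamate receptor 5 (Homo sapiens), read by FLIPR and calcium flux; a lower number here means a stronger inhibitor, a higher number a weaker inhibitor: "not determined" (no result reported)
Compound 2 `Cc1nc2c(cnn2-c2ccccc2)c(=O)n1N1CCCCCC1` in this assay: 3600 nM
Compound 3 `Cc1nc2c(cnn2CC2CCCCC2)c(=O)n1-c1ccc(Cl)cc1` in this assay: > 100000 nM

Of the three compounds measured in this assay, only compound 2 has a single number, and compound 1 has no result. For compound 3 this assay reports only a limit, > 100000 nM. That limit is the value at which one of the three entries sits (the limit of > 100000 nM in this assay, at which 1 of the 3 values shown sits), so compound 3 stands at the weak end of what this assay can report, with no number to compare against compound 2.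

Compound 4 `Cc1nc2c(cnn2-c2ccc(Cl)cc2)c(=O)n1-c1ccc(Cl)cc1` has not yet been measured. It differs from compound 3 in one place (4-chlorophenyl in place of cyclohexylmethyl on an aromatic nitrogen), that is, 4-chlorophenyl in place of cyclohexylmethyl on an aromatic nitrogen. For the measured compounds named here, no step between measured compounds bears on this change. Compound 2, which also carries an aromatic ring on that nitrogen, gives 3600 nM. Compound 3, by contrast, has only a limit in this assay. The two differ in more than one place, so the comparison is loose. Compound 4 is therefore expected to be somewhat stronger than compound 3, with the step from compound 3 to compound 4 estimated at an at least 5.0-fold lower number from compound 3 to compound 4 (0.69 log units; beyond the scatter). For compound 4 an inhibitory concentration around 20000 nM is estimated, within a range from 3000 nM to 100000 nM.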

Compound 4, half-maximal inhibitory concentration: > 100000 nM
Compound 4: a limit, no number; the forecaster's own chance of this, stated with the estimate: 40%; middle value at least 5.0-fold (0.69 log units) from the limit.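

For the compounds shown here, compound 3 and compound 4 each have only a limit in this assay, not a number, so no step between them can be read: the limit of > 100000 nM in this assay, at which 2 of the 4 values shown sit. The compounds shown leave open whether 4-chlorophenyl in place of cyclohexylmethyl on an aromatic nitrogen changes inhibition in this assay at all.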